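The source may hold more compounds than are shown below. What is called first, only, known or untested is meant among the compounds shown, and "the series" means these compounds.

In a functional assay on NCI-H460 cells (Homo sapiens) for cytotoxicity, read by MTT assay, with a stated time of 24 h (a higher number here means a weaker inhibitor, a lower number a stronger inhibitor), compound 1 `C=C[C@@]1(C)[C@H]2OC(=O)C(=C)[C@H]([C@@H]2OC(C)=O)[C@H](OC(=O)C(C)(C)O)[C@@H]1C(=C)C=O` gives 270 nM, while compound 2 `C=C1C(=O)O[C@H]2[C@@H](OC(C)=O)[C@@H]1[C@H](OC(=O)C(C)(C)O)[C@H](C(=C)C=O)[C@@]2(C)[C@@H]1CO1` gives 970 nM, the higher of the two numbers. Compound 3 `C=C1C(=O)O[C@H]2[C@@H](OC(C)=O)[C@@H]1[C@H](OC(=O)C(C)(O)CC)[C@H](C(=C)C=O)[C@@]2(C)[C@@H]1CO1` differs from compound 2 by methyl in place of hydrogen on a saturated chain carbon, two bonds along the chain from a carbonyl carbon and an oxygen on a saturated carbon, turning 1-hydroxy-1-methylethyl into 1-hydroxy-1-methylpropyl. Among the measured compounds shown here, the only measured step, a 3.6-fold higher number from compound 1 to compound 2 (0.56 log units; beyond the scatter), swaps vinyl for oxiran-2-yl elsewhere on the molecule, so it bears on this change only weakly. For the measured compounds named here, no step at this chain has been measured. No change beyond the scatter is therefore expected in this assay, and the estimated step is a 1.1-fold lower number from compound 2 to compound 3 (0.03 log units; within the scatter). Compound 3 is expected at 900 nM, within an estimated range of 400 nM to 2000 nM.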

Compound 3, half-maximal inhibitory concentration: 450 nM
Compound 3: the middle estimate sits 2.0-fold (0.30 log units) above what was measured; measured number inside the range.
By their numbers in this assay, from the lowest: compounds 1 and 3 (each within the scatter of the next); then compound 2.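

In this assay, this chain is no longer silent: turning 1-hydroxy-1-methylethyl into 1-hydroxy-1-methylpropyl, a single methyl in place of hydrogen, gives a 2.2-fold lower number from compound 2 to compound 3 (0.33 log units; beyond the scatter). Among the compounds shown here, the earlier step concerned a different place on the molecule, so this is the first sign that the chain itself affects the read-out, on the background of compound 2 alone. As far as these compounds go, whether a longer chain such as 1-hydroxy-1-methylbutyl would move the number further remains open, as does the outcome of an amine in place of the chain's hydroxy group. Nothing available accounts for the shift.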